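Swapping fluoro for methyl in compound 2

The source may hold more compounds than are shown below. What is called first, only, known or untested is meant among the compounds shown, and "the series" means these compounds.

Measured so far in an ADME assay on CHO cells (Cricetulus griseus) for cytotoxicity, read by LDH release (on this read-out higher numbers stand for weaker inhibition and lower numbers for stronger inhibition), for cytotoxicity:
- compound 1 `CC(Oc1ccc(Cl)cc1Cl)C(=O)NC(CO)c1ccc(F)cc1` gives 18000 nM
- compound 2 `CC(Oc1ccc(Cl)cc1Cl)C(=O)NCc1cccc(F)c1` gives 27000 nM

Going by the values given here, the values of compound 1 and compound 2 lie within the scatter of each other, so compound 2 stands level with the only other measured compound. Compound 3 `Cc1cccc(CNC(=O)C(C)Oc2ccc(Cl)cc2Cl)c1` has methyl in place of fluoro on an aromatic carbon meta to a large group. Among the compounds with values here, no measured pair shows this change. In this assay compound 2 gives 27000 nM, and on the structural change alone the step from it is expected to stay within the scatter. The expected result is a 1.1-fold lower number from compound 2 to compound 3 (0.03 log units; within the scatter) within the scatter. Compound 3 is estimated at 25000 nM with an expected range from 12000 nM to 50000 nM in this assay.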

Compound 3, half-maximal inhibitory concentration: 45000 nM
Compound 3: the middle estimate sits 1.8-fold (0.26 log units) below what was measured, within the range that was stated.
By their numbers in this assay, from the lowest: compounds 1, 2 and 3 (each within the scatter of the next, the first and the last beyond it).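

In this assay, going by these compounds alone, methyl in place of fluoro on an aromatic carbon meta to a large group gives a 1.7-fold higher number from compound 2 to compound 3 (0.22 log units; within the scatter), the first single-place step at this position. Across this one swap, the read-out stays within the scatter. No measurement at hand speaks to what lies behind this result. From the compounds shown here alone, whether an amine, a carboxylic acid or a longer chain on this same carbon would also stay within the scatter remains open. So does whether the same swap would read alike at the fluoro of compound 1.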